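Cytotoxicity in the benzylamine series: compound 2 to compound 3

A few compounds are considered here, and "the series" means these few. Any claim that something is new, unique, unknown or untested is made for them only; others in the source may bear on it.

Compound 2 `COc1cccc(Oc2ccc3c(NCCCNCc4cc(F)ccc4OC)ccnc3c2)c1` gives 7100 nM in an ADME assay on HepG2 cells (Homo sapiens) for cytotoxicity, read by luminescence, CellTiter-Glo and ATP content, with a stated time of 72 h (a lower number here means that less compound is needed, a higher number that more compound is needed for the effect), the highest of the two numbers at hand; the nearest is compound 1 `COc1cccc(CNCCCNc2ccnc3cc(C4CCCCC4)ccc23)c1O`, which in this assay gives 1080 nM, a gap beyond the scatter. Within the data shown here, compound 3 `COc1cccc(Oc2ccc3c(NCCCNCc4cccc(OC)c4O)ccnc3c2)c1` carries 2-hydroxy-3-methoxyphenyl in place of 5-fluoro-2-methoxyphenyl on a saturated chain carbon bound to an amine nitrogen, and shares that group with compound 1, though compound 1 also differs from compound 2 elsewhere on the core, so no single-change step is available. A modest step towards a lower number is expected, a 1.6-fold lower number from compound 2 to compound 3 (0.20 log units; within the scatter), though it may stay within the scatter. Compound 3 is estimated at 4500 nM, within 1500 nM to 13000 nM.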

Compound 3, half-maximal effective concentration: 5300 nM
The estimate for compound 3 lay 1.2-fold (0.07 log units) below the measured number, and the stated range covers the measured number.
By their numbers in this assay, from the lowest: compound 1; then compounds 3 and 2 (each within the scatter of the next).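

In this assay, 2-hydroxy-3-methoxyphenyl in place of 5-fluoro-2-methoxyphenyl gives a 1.3-fold lower number from compound 2 to compound 3 (0.13 log units; within the scatter), so this change on a saturated chain carbon bound to an amine nitrogen does not separate the two compounds. With that group held constant, 3-methoxyphenoxy in place of cyclohexyl on an aromatic carbon gives a 4.9-fold higher number from compound 1 to compound 3 (0.69 log units; beyond the scatter), so the aromatic carbon carries the step beyond the scatter in this set. Nothing available explains either step. Open, going by these compounds, is how a carboxylic acid or a morpholine would read in place of 3-methoxyphenoxy on that aromatic carbon. Also open, on these data alone, is whether 5-fluoro-2-methoxyphenyl and 2-hydroxy-3-methoxyphenyl stay within the scatter on the core of compound 1.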